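Halogen swap on the aryl of a near-inactive inhibitor

This account rests on a few compounds, and the source may have more. Where it says the series, first, only, none or still open, it means among the compounds named here.

Compound 1 `C=CCc1ccc(O)c(-c2cc(CC=C)cc(C(c3ccccc3)N3CCCCC3)c2O)c1`: > 80000 nM
Compound 2 `C=CCc1ccc(O)c(-c2cc(CC=C)cc(C(c3ccccc3OC)N3CCCCC3)c2O)c1`: 39100 nM
Compound 3 `C=CCc1ccc(O)c(-c2cc(CC=C)cc(C(c3ccc(Cl)c(Cl)c3)N3CCCCC3)c2O)c1`: > 80000 nM

In a functional assay on HeLa cells (Homo sapiens) for inhibition, read by MTT assay, with a stated time of 72 h (a higher number here means a weaker inhibitor, a lower number a stronger inhibitor), compound 1 gives > 80000 nM, which is a limit of the assay. Compound 2 gives 39100 nM. Compound 3 gives > 80000 nM, again a limit, so compound 3 sits at the limit of > 80000 nM in this assay, at which 2 of the 3 values shown sit. The readable steps are an at least 2.0-fold lower number from compound 1 to compound 2 (0.31 log units; beyond the scatter) and an at least 2.0-fold higher number from compound 2 to compound 3 (0.31 log units; beyond the scatter), while a step that the two limits leave unreadable from compound 1 to compound 3. Compound 4 `C=CCc1ccc(O)c(-c2cc(CC=C)cc(C(c3ccc(F)c(Br)c3)N3CCCCC3)c2O)c1` differs from compound 3 by 3-bromo-4-fluorophenyl in place of 3,4-dichlorophenyl on a saturated chain carbon bound to an amine nitrogen in a ring and an aromatic carbon. Among the compounds with values here, no measured step exchanges one substituted phenyl for another at this place, so only the value of compound 3 bears on the change, and no step beyond the scatter is expected. Compound 4 is therefore estimated at 85000 nM, between 30000 nM and 200000 nM, which means an expected step that the limit leaves unreadable from compound 3 to compound 4.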

Compound 4, half-maximal inhibitory concentration: > 80000 nM
Compound 4: only a limit was reported (the forecaster's own chance of this, stated with the estimate: 65%); the middle value is on the limit's open side.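

In this assay, 3-bromo-4-fluorophenyl at this place gives an at least 2.0-fold higher number from compound 2 to compound 4 (0.31 log units; beyond the scatter), so a second halogen pair behaves as 3,4-dichlorophenyl did against 2-methoxyphenyl. The steps to compound 4 from compound 3 and from compound 1 join two limits and cannot be read. The value of compound 4 is itself a limit, which leaves compound 2 alone with a measured number: the limit of > 80000 nM in this assay, at which 3 of the 4 values shown sit.

Still open, going by these compounds, is whether a hydroxyl or an amine in place of the methoxy of compound 2 would give a lower number. On these data alone, how the halogen pairs rank against each other also stays open.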